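The source may hold more compounds than are shown below. What is called first, only, known or untested is meant among the compounds shown, and "the series" means these compounds.

Compound 1 `O=C(NCc1ccc(CNS(=O)(=O)c2ccccc2Cl)cc1)c1cccnc1` gives 100 nM in an assay on MDA-MB-231 cells for displacement of a labelled ligand from C-X-C chemokine receptor type 4 (Homo sapiens), read by fluorescence and microscopy, with stated times of 10 min and 30 min; on this read-out higher numbers stand for an effect only at larger amounts of compound and lower numbers for an effect already at smaller amounts. Compound 2 `COc1ccccc1C(=O)NCc1ccc(CNS(=O)(=O)c2cccc(Cl)c2)cc1` gives 1000 nM. Compound 3 `COc1ccccc1C(=O)NCc1ccc(CNS(=O)(=O)c2ccccc2Cl)cc1` gives 100 nM.

Compound 1 stands level with compound 3, as no change at the digits printed from compound 1 to compound 3 (within the scatter) shows, the two together being the lowest of the three numbers; compound 2 lies furthest from compound 1, its number being higher. Compound 4 `Cc1ccccc1S(=O)(=O)NCc1ccc(CNC(=O)c2cccnc2)cc1` differs from compound 1 by methyl in place of chloro on an aromatic carbon. Within the data shown here, no measured step makes this same change. The step of a 10-fold lower number from compound 2 to compound 3 (1.00 log units; beyond the scatter) shows that the sulfonyl-bearing ring is sensitive to where its substituent sits, whereas no change at the digits printed from compound 1 to compound 3 (within the scatter) shows the amide end tolerant of exchange. Since the substituent here keeps its place and only changes from chloro to methyl, compound 4 is expected to move little, a 1.5-fold higher number from compound 1 to compound 4 (0.18 log units; within the scatter), giving an estimated 150 nM, with a range from 50 nM to 500 nM.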

Compound 4, effective concentration (reported as EC, without a stated level of effect): 1000 nM
For compound 4 the middle estimate is 6.7-fold (0.82 log units) below the measured one; measured number above the stated range.
By their numbers in this assay, from the lowest: compounds 1 and 3 (each within the scatter of the next); then compounds 2 and 4 (each within the scatter of the next).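

Methyl in place of chloro, ortho to a large group, brings a 10-fold higher number from compound 1 to compound 4 (1.00 log units; beyond the scatter) in this assay, so this position responds to which group it carries as well as to where that group sits. The earlier compounds shown here had varied only the place of the chloro here. Nothing given here accounts for the difference between the two groups.

From the compounds shown here alone, whether fluoro, bromo or trifluoromethyl at this place would stay level with compound 1 remains open. So does whether the same exchange would give a like step on compound 3, with its 2-methoxyphenyl group.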